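This account rests on a few compounds, and the source may have more. Where it says the series, first, only, none or still open, it means among the compounds named here.

Three compounds have been measured in a functional assay on cells for agonist activity at Free fatty acid receptor 1 (Mus musculus), read by FLIPR and calcium flux, with a stated time of 5 min; a higher number here means a larger maximal response, a lower number a smaller maximal response:
Compound 1, `Cc1nn(-c2ccccn2)c2cc(-c3ccc(CCC(=O)O)cc3)ccc12`: in this assay compound 1 gives 95%.
Compound 2, `Cc1nn(-c2ccccn2)c2cc(-c3ccc(CCC(=O)O)cc3F)ccc12`: compound 2 gives 105%.
Compound 3, `O=C(O)CCc1ccc(-c2ccc3cnn(-c4ccccn4)c3c2)cc1`: compound 3 gives 106%.

Compound 1 stands at the low end of these three numbers, yet its gap to compound 2 lies within the scatter, so only compound 3 sits clearly above it, by a modest amount. Compound 4, `Cc1nn(-c2ccccn2)c2cc(-c3ccc([C@H]4C[C@H]4C(=O)O)cc3)ccc12`, has not been measured. It differs from compound 1 in one place: 2-carboxycyclopropyl in place of 2-carboxyethyl on an aromatic carbon. The two measured steps touch other parts of the shared core: a number 10 percentage points higher from compound 1 to compound 2 (within the scatter) and a number 11 percentage points higher from compound 1 to compound 3 (beyond the scatter). Neither concerns the acid-bearing chain, so nothing measured tells directly how exchanging the 2-carboxyethyl for a 2-carboxycyclopropyl will alter the maximal response. Both measured changes left the response close to that of compound 1, and all three values lie near the control, so the expectation for compound 4 is a step of about no change at the digits printed from compound 1 to compound 4 (within the scatter), that is, nothing beyond the scatter. The estimated value for compound 4 is 95%, with a range from 75% to 112%.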

Compound 4, largest response reached (reported as efficacy), in percent of the reference or control that the assay uses: 81%
Beside the measured number, compound 4's estimate is 14 percentage points above it; low and high end bracket the measured number.
By their numbers in this assay, from the lowest: compound 4; then compounds 1, 2 and 3 (each within the scatter of the next, the first and the last beyond it).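

Exchanging the 2-carboxyethyl for a 2-carboxycyclopropyl on this aromatic carbon gives a number 14 percentage points lower from compound 1 to compound 4 (beyond the scatter) in this assay, so a change to the acid-bearing chain can move the maximal response beyond the scatter. Even so, the step is modest, and with the three-membered ring in the chain compound 4 still reaches 81% in this assay, so this change lowers the response without abolishing it. No measurement at hand offers an explanation for this step.

The compounds shown leave open whether the other arrangements of the two defined stereocentres in the 2-carboxycyclopropyl group would give the same response. They also leave open how a longer chain ending in a carboxylic acid, or a tetrazole in place of that acid, would behave at this position.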